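A few compounds are considered here, and "the series" means these few. Any claim that something is new, unique, unknown or untested is made for them only; others in the source may bear on it.

Of the compounds shown here, three sharing one core have been tested for their effect on the growth of Z-138 cells. Compound 1 `Nc1ncnn2c([C@@H]3O[C@H](CO)[C@@H](O)[C@H]3O)cc(C#Cc3cccs3)c12` gives 50100 nM in a functional assay on Z-138 cells (Homo sapiens) for antiproliferative activity, with a stated time of 72 h; on this read-out higher numbers stand for weaker inhibition and lower numbers for stronger inhibition. Compound 2 `Nc1ncnn2c([C@@H]3O[C@H](CO)[C@@H](O)[C@H]3O)cc(-c3ccc(Cl)cc3)c12` gives 40200 nM in this assay, and compound 3 `Nc1ncnn2c([C@@H]3O[C@H](CO)[C@@H](O)[C@H]3O)cc(-c3ccc(F)cc3F)c12` gives 59100 nM in this assay. Compound 3 has the highest of the three numbers, yet its step from compound 1 is a 1.2-fold higher number from compound 1 to compound 3 (0.07 log units; within the scatter) and its step from compound 2 is a 1.5-fold higher number from compound 2 to compound 3 (0.17 log units; within the scatter), so none of the three can be told apart with confidence.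

The next compound, compound 4 `Nc1ncnn2c([C@@H]3O[C@H](CO)[C@@H](O)[C@H]3O)cc(-c3ccccc3Cl)c12`, differs from compound 3 in one place: 2-chlorophenyl in place of 2,4-difluorophenyl on an aromatic carbon. The steps seen so far all exchange one flat aromatic group for another on the same carbon of the core, and each of them was small: a 1.2-fold lower number from compound 1 to compound 2 (0.10 log units; within the scatter), a 1.2-fold higher number from compound 1 to compound 3 (0.07 log units; within the scatter) and a 1.5-fold higher number from compound 2 to compound 3 (0.17 log units; within the scatter). The exchange of 2,4-difluorophenyl for 2-chlorophenyl is of the same kind, a halogenated six-membered ring replacing another. Because of a 1.5-fold higher number from compound 2 to compound 3 (0.17 log units; within the scatter), in which 2,4-difluorophenyl and 4-chlorophenyl proved interchangeable, no step beyond the scatter is expected in this assay here either. The step from compound 3 to compound 4 is therefore estimated as a 1.2-fold lower number from compound 3 to compound 4 (0.07 log units; within the scatter). Compound 4 is expected to give about 50000 nM in this assay, with a range from 20000 nM to 125000 nM.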

Compound 4, half-maximal inhibitory concentration: 76100 nM
Compound 4: the middle estimate sits 1.5-fold (0.18 log units) below what was measured, and the stated range covers the measured number.
By their numbers in this assay, from the lowest: compounds 2, 1, 3 and 4 (each within the scatter of the next).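

Within the data shown here, the pair of compound 2 and compound 4 is the first in which the same chlorine-bearing phenyl ring appears with its chlorine at two different ring places, and a 1.9-fold higher number from compound 2 to compound 4 (0.28 log units; within the scatter) shows that, in this assay, 2-chlorophenyl and 4-chlorophenyl cannot be told apart at this carbon of the shared core. The other two new steps, a 1.3-fold higher number from compound 3 to compound 4 (0.11 log units; within the scatter) and a 1.5-fold higher number from compound 1 to compound 4 (0.18 log units; within the scatter), also stay within the scatter, so the four compounds cannot be separated, and the substituent changes tried at this position have yet to give a measurable shift in either direction. No independent measurement is available to explain this flat result.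

From the compounds shown here alone, all four compounds carry an aromatic ring at this carbon, either directly or through the ethynyl link of compound 1, so it remains open whether a primary amine, a carboxylic acid or a simple alkyl chain there would give a step beyond the scatter. Going by these compounds, all four also share the 3,4-dihydroxy-5-(hydroxymethyl)oxolan-2-yl group, so the effect of changing that part of the molecule remains open too.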